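Isopropyl to Isobutyl on the Amide of Compound 3

This account rests on a few compounds, and the source may have more. Where it says the series, first, only, none or still open, it means among the compounds named here.

Three compounds have been measured in a functional assay on HeLa cells (Homo sapiens) for antiproliferative activity, read by CCK-8 assay, with a stated time of 72 h; on this read-out lower numbers stand for stronger inhibition of growth and higher numbers for weaker inhibition of growth:

Compound 1, `CC[C@@H]1C(=O)N(C)c2cnc(-n3ccc4cc(F)ccc43)nc2N1C1CCCC1`: "not active" (no number reported)
Compound 2, `CCCNS(=O)(=O)c1ccc(Nc2ncc3c(n2)N(c2ccn(C)n2)C(CC)C(=O)N3C)cc1`: 2670 nM
Compound 3, `CC[C@@H]1C(=O)N(C)c2cnc(-n3ccc4cc(C(=O)NC(C)C)ccc43)nc2N1C1CCCC1`: 292 nM

Compound 3 gives the lowest number of the two reported. Compound 2, which shares little of its structure beyond the core, stands well above it, beyond the scatter, and compound 1 was reported as not active without a number. Compound 3 is therefore the reference point for the next step.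

Compound 4, `CC[C@@H]1C(=O)N(C)c2cnc(-n3ccc4cc(C(=O)NCC(C)C)ccc43)nc2N1C1CCCC1`, differs from compound 3 in one place: isobutyl in place of isopropyl on an amide-type nitrogen. The chain on the amide nitrogen grows by one carbon and branches further out, while the rest of the molecule is kept.

Within the data shown here, no measured pair shows this change, so nothing here sets its size. A change of this kind, at the end of a chain with no donor or acceptor gained or lost, is expected to move the number little, if at all, and the step from compound 3 is estimated as a 1.2-fold higher number from compound 3 to compound 4 (0.08 log units; within the scatter), within the scatter. For compound 4 the value is estimated at 350 nM, with a range of 120 nM to 1000 nM.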

Compound 4, concentration for 50% growth inhibition: 3280 nM
Estimate against measurement, compound 4: 9.4-fold (0.97 log units) below, outside the stated range (above it).
By their numbers in this assay, from the lowest: compound 3; then compounds 2 and 4 (each within the scatter of the next).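

The amide nitrogen turns out to be a sensitive position: exchanging isopropyl for isobutyl there gives an 11-fold higher number from compound 3 to compound 4 (1.05 log units; beyond the scatter) in this assay. By count the change is slight, with one carbon more in the group that enters and no ring, hydrogen-bond donor, hydrogen-bond acceptor or net charge on either side, yet that alone is enough to separate the two compounds well beyond the scatter. Nothing available here accounts for a step of this size.

Still open, on these data alone, is whether a shorter chain such as ethyl or methyl, or a small ring such as cyclopropyl, on this nitrogen would hold or better the number of compound 3. Also open, as far as these compounds go, is how a longer chain, or an amine or carboxylic acid at the end of the chain, would read in this assay.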